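Swapping Bromo for Methoxy: Expected Effect on Solubility

The compounds below may be only part of what the source reports. "The series", "measured", "known", "first", "only" and "open" are said of these compounds alone.

Compound 1 `O=C(Nc1nc(-c2cccc(C(F)(F)F)c2F)cs1)c1cnc(N2CCC(C(=O)O)CC2)c(Br)c1` was measured in a physicochemical assay for solubility; a lower number here means a less soluble compound, a higher number a more soluble compound. In this assay compound 1 gives < 10 ug/mL, which is a limit of the assay rather than a number. Compound 2 `O=C(Nc1nc(-c2cccc(C(F)(F)F)c2F)cs1)c1ccc(N2CCC(C(=O)O)CC2)c(Cl)c1` likewise returns < 10 ug/mL, again a limit. Both values thus sit at the limit of < 10 ug/mL in this assay, at which 2 of the 2 values shown sit. Compound 3 `COc1cc(C(=O)Nc2nc(-c3cccc(C(F)(F)F)c3F)cs2)cnc1N1CCC(C(=O)O)CC1` differs from compound 1 by methoxy in place of bromo on an aromatic carbon. For the measured compounds named here, no measured step of this kind exists, so the shift expected from compound 1 to compound 3 is a step that the limit leaves unreadable from compound 1 to compound 3, likely not beyond the scatter. Compound 3 is therefore estimated at 8 ug/mL, within 2 ug/mL to 30 ug/mL.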

Compound 3, solubility: < 10 ug/mL
Compound 3 was reported as a limit (the forecaster's own chance of this, stated with the estimate: 60%); the middle value does not contradict the limit.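

Compounds 1 and 3 both return only a limit in this assay, so no step between them can be read: the limit of < 10 ug/mL in this assay, at which 3 of the 3 values shown sit.

What these compounds leave open is the true size of the difference between bromo and methoxy at this place.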